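Allyloxy for pyridin-2-yl on the shared core

This account rests on a few compounds, and the source may have more. Where it says the series, first, only, none or still open, it means among the compounds named here.

Compound 2 `Cc1cc(-c2ccccn2)cc(C(=O)NNS(=O)(=O)c2ccccc2)c1F` gives 424 uL/min in an ADME assay on microsomes from liver (Mus musculus) for metabolic stability, read by HPLC, using NADPH, with a stated time of 60 min, tested at 1 uM, in the presence of a further agent that is not named here (a higher number here means faster removal of the compound, a lower number slower removal), the lowest of the two numbers shown. For the measured compounds named here, its only neighbour is compound 1 `Cc1cc(-n2nccn2)cc(C(=O)NNS(=O)(=O)c2ccccc2)c1F`, which in this assay gives 865 uL/min; the step of a 2.0-fold lower number from compound 1 to compound 2 (0.31 log units; beyond the scatter) is the one measured change at this position of the core, pyridin-2-yl in place of 2H-1,2,3-triazol-2-yl on an aromatic carbon.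

Compound 3 `C=CCOc1cc(C)c(F)c(C(=O)NNS(=O)(=O)c2ccccc2)c1` is not yet measured. It differs from compound 2 in one place: allyloxy in place of pyridin-2-yl on an aromatic carbon

Going by the values given here, no measured step covers allyloxy at this position, and none covers a group without a ring there. Among the compounds with values here, the single step that exists at this carbon, from one ring to another, was modest in size. With nothing that bears directly on the new group, the account treats the change as an open question and expects no step beyond the scatter, while allowing a wide range in either direction.

For compound 3 the estimate in this assay is 600 uL/min, with a range from 250 uL/min to 1500 uL/min, which would mean an expected step of a 1.4-fold higher number from compound 2 to compound 3 (0.15 log units; within the scatter).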

Compound 3, intrinsic clearance in a liver preparation (reported as CLH), per the amount of preparation that the assay uses: > 866 uL/min
Compound 3: only a limit was reported; the forecaster's own chance of this, stated with the estimate: 5%; middle value at least 1.4-fold (0.15 log units) away from the limit.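

In this assay compound 3 gives > 866 uL/min, and this value is a limit of the assay, not a number. For the compounds shown here, until now this aromatic carbon had carried only rings, and the one step there ran between two of them; allyloxy is the first group without a ring at this position, and in place of pyridin-2-yl it gives an at least 2.0-fold higher number from compound 2 to compound 3 (0.31 log units; beyond the scatter), so the step is readable only as a minimum and the true change may be larger. Compound 2 thus keeps the lowest number of the three, while the step of a number no lower from compound 1 to compound 3 (the limit leaves the size open) cannot be read for size, and nothing shown explains the result beyond the limit itself: the limit of > 866 uL/min in this assay, at which 1 of the 3 values shown sits.

The compounds shown leave open whether the faster removal of compound 3 goes with the ether oxygen, the double bond or the absence of a ring, and a saturated propoxy chain, a methoxy group or a phenyl ring at this carbon would begin to separate these. They also leave open how far past its limit compound 3 truly lies.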